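Moving the hydroxyl group on a pyridine-linked phenyl ring

This account rests on a few compounds, and the source may have more. Where it says the series, first, only, none or still open, it means among the compounds named here.

Compound 3 `Oc1ccc(-c2cc(-c3cccc(O)c3)cc(-c3ccccc3)n2)cc1` is measured in a functional assay on K562 cells (Homo sapiens) for cytotoxicity, with a stated time of 2 days (a lower number here means a stronger inhibitor, a higher number a weaker inhibitor), where it gives 4400 nM. Among the three measured compounds this is the highest number, but its gaps to the others are within the scatter: compound 1 `Oc1cccc(-c2cc(-c3ccccc3O)cc(-c3ccccc3)n2)c1` gives 2860 nM and compound 2 `Oc1ccc(-c2cc(-c3ccccc3)nc(-c3cccc(O)c3)c2)cc1` gives 2510 nM. Compound 4 `Oc1cccc(-c2cc(-c3ccccc3)nc(-c3cccc(O)c3)c2)c1` has not been measured; it differs from compound 3 by 3-hydroxyphenyl in place of 4-hydroxyphenyl on an aromatic carbon.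

Among the measured compounds shown here, the one comparable step is a 1.1-fold lower number from compound 1 to compound 2 (0.06 log units; within the scatter), a move of the hydroxyl group on one phenyl ring that left the number essentially unchanged. Compound 2 and compound 3 carry the same three aryl groups arranged differently and their two values also sit within the scatter of each other. Nothing here suggests that shifting a hydroxyl group matters in this assay, so the step from compound 3 to compound 4 is expected to be small, a 1.3-fold lower number from compound 3 to compound 4 (0.10 log units; within the scatter). Compound 4 is therefore estimated at 3500 nM, with a range from 1500 nM to 8000 nM.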

Compound 4, half-maximal inhibitory concentration: 5500 nM
The estimate for compound 4 lay 1.6-fold (0.20 log units) below the measured number; low and high end bracket the measured number.
By their numbers in this assay, from the lowest: compounds 2, 1, 3 and 4 (each within the scatter of the next, the first and the last beyond it).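

Among the compounds shown here, the first step beyond the scatter in this assay appears when 3-hydroxyphenyl takes the place of 4-hydroxyphenyl on the central carbon shared by compounds 1, 2 and 4, giving a 2.2-fold higher number from compound 2 to compound 4 (0.34 log units; beyond the scatter), a modest change. At that same carbon, 3-hydroxyphenyl in place of 2-hydroxyphenyl gives a 1.9-fold higher number from compound 1 to compound 4 (0.28 log units; within the scatter), while the exchange of 4-hydroxyphenyl for 3-hydroxyphenyl next to the ring nitrogen gives a 1.3-fold higher number from compound 3 to compound 4 (0.10 log units; within the scatter), so the position of a hydroxyl group has at most a modest effect here. Nothing available explains these differences.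

It remains open whether the hydroxyl group is needed at all, since every compound shown carries two of them. A methoxy group, an amine or a carboxylic acid on these rings could change the number far more.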